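Hydrazone series on a shared core: toward compound 4

This account rests on a few compounds, and the source may have more. Where it says the series, first, only, none or still open, it means among the compounds named here.

Measured so far:
compound 1 `O=C(Cc1csc2nc(-c3ccc(Br)cc3)cn12)N/N=C/c1ccccc1`: 37200 nM
compound 2 `O=C(Cc1csc2nc(-c3ccc(Br)cc3)cn12)N/N=C/c1ccccc1O`: 5250 nM
compound 3 `O=C(Cc1csc2nc(-c3ccc(Br)cc3)cn12)N/N=C/c1ccc(O)cc1`: 31600 nM

In a functional assay on T47D cells (Homo sapiens) for inhibition, read by sulforhodamine B assay, with a stated time of 48 h (a higher number here means a weaker inhibitor of growth, a lower number a stronger inhibitor of growth), compound 3 stands second highest of the three numbers; one neighbouring step is small (a 1.2-fold lower number from compound 1 to compound 3 (0.07 log units; within the scatter)) and the other is wide (a 6.0-fold higher number from compound 2 to compound 3 (0.78 log units; beyond the scatter)). Compound 4 `O=C(Cc1csc2nc(-c3ccc(Br)cc3)cn12)N/N=C/c1ccc(Cl)cc1Cl` differs from compound 3 in one place: 2,4-dichlorophenyl in place of 4-hydroxyphenyl on a carbon with a double bond to nitrogen. Among the measured compounds shown here, no measured step swaps a hydroxy for a chlorine, so the bearing steps are indirect: a 7.1-fold lower number from compound 1 to compound 2 (0.85 log units; beyond the scatter) shows that a substituent at the first-named position of the entering group can matter, whereas a 1.2-fold lower number from compound 1 to compound 3 (0.07 log units; within the scatter) shows little effect at the other. On that basis a modest drop in the number is expected for compound 4, a 2.1-fold lower number from compound 3 to compound 4 (0.32 log units; beyond the scatter), with wide uncertainty. The estimate for compound 4 in this assay is 15000 nM, spanning 4000 nM to 50000 nM.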

Compound 4, concentration for 50% growth inhibition: < 100000 nM
Compound 4 ended at the assay's limit; the forecaster's own chance of this, stated with the estimate: 10%; the middle value does not contradict the limit.
By their numbers in this assay, from the lowest: compound 2; then compounds 3 and 1 (each within the scatter of the next).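

In this assay compound 4 gives < 100000 nM, a limit of the assay and not a number. Its steps from compound 1, compound 2 and compound 3 cannot be read. The compounds shown leave open how 2,4-dichlorophenyl compares with phenyl, 2-hydroxyphenyl or 4-hydroxyphenyl.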